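This account rests on a few compounds, and the source may have more. Where it says the series, first, only, none or still open, it means among the compounds named here.

Working notes on the series.

The series shares one core; compound 1 is `COc1cccc(CCCNC(C)=O)c1` and compound 2 is `CCCC(=O)NCCCc1cccc(OC)c1`. In an assay for binding affinity to melatonin receptor (Gallus gallus) (on this read-out lower numbers stand for stronger inhibition and higher numbers for weaker inhibition), compound 1 gives 63 nM, while compound 2 gives 5.5 nM. Among the compounds with values here, the one measured step is an 11-fold lower number from compound 1 to compound 2 (1.06 log units; beyond the scatter). Compound 2 therefore stands at the lowest of the two numbers shown, with compound 1 as its only neighbour.

The next compound, compound 3, is `CCCC(=O)NCCCc1cccc(Br)c1`. It differs from compound 2 by bromo in place of methoxy on an aromatic carbon. Within the data shown here, no measured step touches the substituent on the aromatic ring: the single step from compound 1 to compound 2 sits on the saturated chain at the carbonyl side and gives no guide to a change on the ring, neither in direction nor in size. The expected step from compound 2 to compound 3 in this assay is therefore taken as a 1.8-fold higher number from compound 2 to compound 3 (0.26 log units; within the scatter), with wide uncertainty on both sides. On that basis compound 3 is estimated at 10 nM, within a range of 2 nM to 60 nM.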

Compound 3, inhibition constant: 354 nM
Compound 3: middle estimate off by 35-fold (1.55 log units), on the low side; measured number above the stated range.
By their numbers in this assay, from the lowest: compound 2; then compound 1; then compound 3.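

The aromatic carbon bearing the methoxy in compound 2 proves highly sensitive in this assay: bromo in place of methoxy gives a 64-fold higher number from compound 2 to compound 3 (1.81 log units; beyond the scatter), a large step in the opposite direction to the chain change, which gave an 11-fold lower number from compound 1 to compound 2 (1.06 log units; beyond the scatter). Within these three compounds, the ring substituent therefore matters at least as much as the saturated chain at the carbonyl side, and the gain seen in compound 2 does not protect it against this exchange. The exchange swaps two heavy atoms and one hydrogen-bond acceptor for one heavy atom and no acceptor, but nothing available explains the size of the step.

From the compounds shown here alone, with only methoxy and bromo at this place, it remains open which feature of the methoxy counts, and whether a hydroxy, an ethoxy or a chloro would read closer to compound 2 or to compound 3. Going by these compounds, it is also open whether the same exchange on the core of compound 1 would give a step of similar size, or whether the ring and chain changes depend on each other.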